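Shortening the Chain on the Aromatic Nitrogen

This account rests on a few compounds, and the source may have more. Where it says the series, first, only, none or still open, it means among the compounds named here.

In a functional assay with Alpha-1D adrenergic receptor (Homo sapiens) as the target, read by calcium flux (a lower number here means a smaller maximal response, a higher number a larger maximal response), compound 3 `CCn1nccc1-c1ccccc1NCC1=NCCN1` gives 0%. This places compound 3 level with compound 1 `CCn1ccc(-c2ccccc2NCC2=NCCN2)n1`, which gives 0%, the two together being the lowest values among the three measured compounds. Compound 2 `c1ccc(-c2cn[nH]c2)c(NCC2=NCCN2)c1`, which carries no chain on that position, gives 62%, far beyond the scatter above compound 3. Compound 4 `Cn1nccc1-c1ccccc1NCC1=NCCN1` has not yet been measured; it differs from compound 3 by hydrogen in place of methyl on a saturated chain carbon bound to an aromatic nitrogen. Since the chain stays in place and only shrinks, the maximal response of compound 4 is expected to stay near the floor, with the step of a number 5 percentage points higher from compound 3 to compound 4 (within the scatter) estimated as a small rise within the scatter. Compound 4 is therefore expected to give 5%, within 0% to 30%.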

Compound 4, largest response reached (reported as maximal response), in percent of the reference or control that the assay uses: 0%
The estimate for compound 4 lay 5 percentage points above the measured number; low and high end bracket the measured number.
By their numbers in this assay, from the lowest: compounds 1, 3 and 4 (each within the scatter of the next); then compound 2.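

Cutting ethyl to methyl, that is, hydrogen in place of methyl on a saturated chain carbon bound to an aromatic nitrogen, gives in this assay no change at the digits printed from compound 3 to compound 4 (within the scatter), so this shorter chain brings no response back. The swap of 1H-pyrazol-4-yl for 1-methyl-1H-pyrazol-5-yl on an aromatic carbon gives a number 62 percentage points lower from compound 2 to compound 4 (beyond the scatter), a large step, though it changes the methyl and the ring's point of attachment together.

As far as these compounds go, whether a bare 1H-pyrazol-5-yl, or a primary amine on that chain, would restore a response stays open. No measurement here explains these numbers.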